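A Longer Chain on Compound 3: What to Expect

The compounds below may be only part of what the source reports. "The series", "measured", "known", "first", "only" and "open" are said of these compounds alone.

In a functional assay on HCT-8 cells (Homo sapiens) for cytotoxicity (on this read-out higher numbers stand for weaker inhibition and lower numbers for stronger inhibition), compound 3 (`C#C[C@H](O)/C=C/CCCCC/C=C\CCCC/C=C\CCCCCCCCC/C=C/[C@@H](O)C#C`) gives 160 nM and stands level with its two measured relatives. Compound 1 (`C#C[C@H](O)/C=C/CCCCCCCCC/C=C\CCCCCCCCC/C=C/[C@@H](O)C#C`) gives 160 nM and compound 2 (`C#C[C@H](O)/C=C/CCCCCCCCC/C=C\CCCCCCCCCCC/C=C/[C@@H](O)C#C`) gives 160 nM on the same read-out.

The next compound, compound 4 (`C#C[C@H](O)/C=C/CCCCCCC/C=C\CCCC/C=C\CCCCCCCCC/C=C/[C@@H](O)C#C`), comes from compound 3 through one structural change: a group of 8 heavy atoms (7 carbon, 1 oxygen; no ring) in place of a group of 6 heavy atoms (5 carbon, 1 oxygen; no ring), on a saturated chain carbon, five bonds along the chain from a double-bonded chain carbon in the chain. A larger group replaces a smaller one, on a saturated chain carbon, five bonds along the chain from a double-bonded chain carbon.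

For the measured compounds named here, only one measured step bears on this. It is no change at the digits printed from compound 1 to compound 2 (within the scatter) for a swap of the same size, made nine bonds along the chain from a double-bonded chain carbon instead. That step sits at a different place and is a single example, so the evidence is thin. Even so, it gives no reason to expect movement in this assay here.

The expected result is no change at the digits printed from compound 3 to compound 4 (within the scatter) and nothing beyond the usual scatter is expected. Compound 4 is expected at 160 nM and estimated to fall from 70 nM to 350 nM when measured.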

Compound 4, half-maximal inhibitory concentration: 160 nM
The estimate for compound 4 equals the measured number at the digits printed; measured number inside the range.
By their numbers in this assay, from the lowest: compounds 1, 2, 3 and 4 (each within the scatter of the next).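

In this assay, putting the group of 8 heavy atoms in place of the group of 6 heavy atoms, on a saturated chain carbon, five bonds along the chain from a double-bonded chain carbon, gives no change at the digits printed from compound 3 to compound 4 (within the scatter). Until now this swap had been seen only nine bonds along the chain from a double-bonded chain carbon, so there was a single example; now the same swap reads alike at a second place and on a second core: the same change on two cores in this assay, no change at the digits printed (within the scatter) from compound 1 to compound 2 and no change at the digits printed (within the scatter) from compound 3 to compound 4, 1.0-fold (0.00 log units) apart, within the scatter of two such steps Within these four compounds, then, this change in chain length leaves the read-out flat at both places.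

As far as these compounds go, what a much longer chain would do at this position remains open. So does the effect of an amine or a carboxylic acid placed on the chain there.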